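Removal of the ring methyl from compound 1

The compounds below may be only part of what the source reports. "The series", "measured", "known", "first", "only" and "open" are said of these compounds alone.

Two compounds in this series have numbers in a functional assay on NCI-H460 cells (Homo sapiens) for antiproliferative activity; on this read-out lower numbers stand for stronger inhibition of growth and higher numbers for weaker inhibition of growth. Compound 1 `Cc1cnc2nc(-c3ccc4ccccc4c3)cc(O)c2c1` gives 398 nM, the higher of the two. Compound 2 `Cc1cc(C)c2c(O)cc(-c3cccc(Cl)c3)nc2n1` gives 224 nM, which lies within the scatter of compound 1. Compound 3 `Oc1cc(-c2ccc3ccccc3c2)nc2ncccc12` has not yet been measured; it differs from compound 1 by hydrogen in place of methyl on an aromatic carbon. Within the data shown here, no measured pair shows the effect of this change, so its size is unknown from the data. A step from compound 1 to compound 3 of no more than the scatter is expected, in either direction. Compound 3 is expected to give 500 nM, within 160 nM to 1600 nM. The expected step is a 1.3-fold higher number from compound 1 to compound 3 (0.10 log units; within the scatter).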

Compound 3, concentration for 50% growth inhibition: 3800 nM
Compound 3: the middle estimate sits 7.6-fold (0.88 log units) below what was measured, outside the stated range (above it).
By their numbers in this assay, from the lowest: compounds 2 and 1 (each within the scatter of the next); then compound 3.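

In this assay, the methyl on this aromatic carbon, two atoms from the ring nitrogen, proves to matter: hydrogen in its place gives a 9.5-fold higher number from compound 1 to compound 3 (0.98 log units; beyond the scatter) in a step beyond the scatter. Among these compounds, this is the first pair that differs in one place, and it shows that this position responds to change, with the methyl compound holding the lower number. No measurement at hand offers a reason for the step. From the compounds shown here alone, whether an ethyl group, a chlorine or a methoxy group at this carbon would match the methyl remains open. Also open, going by these compounds, is whether the step carries over to a core other than that of compound 1.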